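The source may hold more compounds than are shown below. What is called first, only, known or untested is meant among the compounds shown, and "the series" means these compounds.

Measured in a functional assay on OVCAR-3 cells (Homo sapiens) for inhibition; a lower number here means a stronger inhibitor of growth, a higher number a weaker inhibitor of growth:

- compound 1, `CC(=O)CC/C=C(\C)CCC1=C(C)CCCC1(C)C`: compound 1 gives > 15000 nM.
- compound 2, `C=C1CCC[C@H]2[C@](C)(CC[C@]3(C)CC[C@@H]([C@@H](C)C(=O)O)OO3)[C@@H](C)CC[C@]12C`: compound 2 gives 990 nM.

The value of compound 1 is a limit of this assay and not a number (the limit of > 15000 nM in this assay, at which 1 of the 2 values shown sits). Among the compounds with values here, compound 2 therefore stands as the only compound with a numerical value in this assay, and no step between measured compounds can be computed from the two entries.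

The next compound, compound 3, `C=C1CCC[C@H]2[C@](C)(CC[C@]3(C)CC[C@H]([C@@H](C)C(=O)O)OO3)[C@@H](C)CC[C@]12C`, remains to be measured in this assay. Its relation to compound 2 is the two compounds have the same atoms and bonds and differ only in configuration as drawn: 1 of 7 stereo elements differ; a stereocentre at a saturated ring carbon is drawn S in compound 2 and R in compound 3. The change thus leaves every atom and bond in place and turns over a single stereocentre at a saturated ring carbon.

Nothing in the measured pair shows how this assay responds to a change of configuration alone. Where a single ring stereocentre is inverted, the expected outcome is a step in this assay of no more than modest size, with no clear direction from the data, and the estimate for compound 3 is placed close to the value of compound 2 with a wide range to cover either outcome. The expected step from compound 2 to compound 3 is a 1.5-fold higher number from compound 2 to compound 3 (0.18 log units; within the scatter). Compound 3 is expected to give 1500 nM, within 400 nM to 6000 nM.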

Compound 3, concentration for 50% growth inhibition: 1850 nM
The estimate for compound 3 lay 1.2-fold (0.09 log units) below the measured number; measured number inside the range.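

In this assay, turning over the stereocentre at a saturated ring carbon gives a 1.9-fold higher number from compound 2 to compound 3 (0.27 log units; within the scatter), a step within the scatter. Within the data shown here, this is the first reading of a change at this position, and with every atom and bond left in place, the two drawn configurations cannot be told apart by this read-out, so the growth inhibition seen here shows no dependence on configuration at this one carbon: the fact that compounds 2 and 3 differ only in the configuration as drawn. Among these compounds, compound 1 remains a limit and not a number, so no step to it can be read and it adds nothing on this position: the limit of > 15000 nM in this assay, at which 1 of the 3 values shown sits.

On these data alone, the other stereo elements stay untested by these compounds, since only this one differs, and a single inversion says nothing about whether the same indifference would hold at any of the remaining centres. Also open, as far as these compounds go, is how this assay would respond to a change of group rather than of configuration, for instance a methyl ester or a primary amide in place of the carboxylic acid, on either of the two configurations.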